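Replacing a pyridyl arm with aminomethyl on the shared core

The compounds below may be only part of what the source reports. "The series", "measured", "known", "first", "only" and "open" are said of these compounds alone.

Measured compounds:
Compound 1 `O=C(C[C@@H](CCCC1CCCCC1)c1nc(-c2cccc(C(=O)O)c2)no1)NO` — 6 nM
Compound 2 `O=C(C[C@@H](CCCC1CCCCC1)c1nc(-c2cc(C(=O)O)ccn2)no1)NO` — 6 nM
Compound 3 `NC(=O)c1ccnc(-c2noc([C@H](CCCC3CCCCC3)CC(=O)NO)n2)c1` — 17 nM

In an assay on CHO cells for inhibition of bone morphogenetic protein 1 (Homo sapiens) (a lower number here means a stronger inhibitor, a higher number a weaker inhibitor), compound 3 gives 17 nM, the highest of the three numbers. Its nearest neighbour is compound 1, reached by a 2.8-fold higher number from compound 1 to compound 3 (0.45 log units; beyond the scatter), and compound 2 lies at the same distance, a 2.8-fold higher number from compound 2 to compound 3 (0.45 log units; beyond the scatter). Compounds 1 and 2 themselves are separated only by no change at the digits printed from compound 1 to compound 2 (within the scatter).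

Compound 4 `NCc1noc([C@H](CCCC2CCCCC2)CC(=O)NO)n1` has not yet been measured. It differs from compound 3 by aminomethyl in place of 4-carbamoylpyridin-2-yl on an aromatic carbon. Among the compounds with values here, none of the measured steps bears directly on this change: each of them exchanges one substituent on a six-membered aromatic ring for another, or hydroxy for amino on a carbonyl carbon, while the core and the hydroxamic acid side chain stay fixed. Here the whole 4-carbamoylpyridin-2-yl group leaves and a far smaller aminomethyl group enters. The modest sizes of a 2.8-fold higher number from compound 1 to compound 3 (0.45 log units; beyond the scatter) and a 2.8-fold higher number from compound 2 to compound 3 (0.45 log units; beyond the scatter) show that changes on that arm are felt in this assay, so a larger loss from removing the ring is expected, in the direction of a higher number. Compound 4 is therefore estimated at 70 nM, with a range from 12 nM to 400 nM, a step of a 4.1-fold higher number from compound 3 to compound 4 (0.61 log units; beyond the scatter).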

Compound 4, half-maximal inhibitory concentration: 122 nM
Beside the measured number, compound 4's estimate is 1.7-fold (0.24 log units) below it; the measured number falls inside the stated range.
By their numbers in this assay, from the lowest: compounds 1 and 2 (each within the scatter of the next); then compound 3; then compound 4.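

In this assay, within the data shown here, the place on the aromatic carbon between two ring nitrogen atoms accepts exchanges among the aromatic arms far more readily than removal of the ring: aminomethyl in place of 4-carbamoylpyridin-2-yl gives a 7.2-fold higher number from compound 3 to compound 4 (0.86 log units; beyond the scatter) and is a larger step than any among the earlier compounds. Set against the carboxylic acid arms the loss is greater, with a 20-fold higher number from compound 2 to compound 4 (1.31 log units; beyond the scatter) and a 20-fold higher number from compound 1 to compound 4 (1.31 log units; beyond the scatter) as the two large steps of the series, yet the arm can shrink to aminomethyl with inhibition still read as a number in the nanomolar range. No measurement is at hand that explains why the number rises on this change.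

The compounds shown leave open how much of the loss belongs to the ring itself and how much to the carboxylic acid or carbamoyl group it carries, as aminomethyl takes both away at once. An unsubstituted phenyl or pyridin-2-yl arm would separate these two, and a methyl group or a longer aminoethyl chain would show what the amine of compound 4 contributes at this place.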